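The compounds below may be only part of what the source reports. "The series", "measured", "known", "first", "only" and "open" are said of these compounds alone.

Measured in a functional assay on cells (Erythrocyte, Rattus norvegicus) for inhibition, read by hemolysis, with a stated time of 1 h; on this read-out lower numbers stand for stronger inhibition and higher numbers for weaker inhibition:
Compound 1 `COc1cc(OC)c(OC)cc1/C=C/C(=O)c1cc(OC(C)=O)ccc1OC(C)=O`: 2.33 ug/mL
Compound 2 `COc1ccc(C(=O)/C=C/c2cc(OC)c(OC)cc2OC)cc1`: 2.18 ug/mL
Compound 3 `COc1cc(OC)c(-c2cc(=O)c3cc(Cl)ccc3o2)cc1OC`: 2.13 ug/mL

In this assay, compound 2 gives 2.18 ug/mL, a number within the scatter of those of both other compounds, so the three stand level. Compound 4 `COc1cc(OC)c(OC)cc1/C=C/C(=O)c1cc(Cl)ccc1O` has not yet been measured. It carries 5-chloro-2-hydroxyphenyl in place of 4-methoxyphenyl on a carbonyl carbon. Among the compounds with values here, no measured pair shows this change alone. Still, compound 1 at 2.33 ug/mL and compound 3 at 2.13 ug/mL sit level with compound 2 despite their different structures, so no step beyond the scatter is expected. The expected step is a 1.0-fold higher number from compound 2 to compound 4 (0.00 log units; within the scatter). For compound 4 the estimated value is 2.2 ug/mL, with an expected range of 1.1 ug/mL to 4.4 ug/mL.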

Compound 4, half-maximal inhibitory concentration: 2.23 ug/mL
Beside the measured number, compound 4's estimate is 1.0-fold (0.01 log units) below it; the measured number falls inside the stated range.
By their numbers in this assay, from the lowest: compounds 3, 2, 4 and 1 (each within the scatter of the next).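

In this assay, placing 5-chloro-2-hydroxyphenyl in place of 4-methoxyphenyl on the carbonyl carbon gives a 1.0-fold higher number from compound 2 to compound 4 (0.01 log units; within the scatter), the first single-place comparison available here. The two compounds stand level, so this position accepts either ring with no difference that this read-out can separate. Nothing measured here offers an explanation for this.

Chlorine and the hydroxyl enter together, so what each does alone stays open. Going by these compounds, it also stays open whether an amine or a carboxylic acid on this ring would stand level too.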